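The source may hold more compounds than are shown below. What is called first, only, known or untested is meant among the compounds shown, and "the series" means these compounds.

Of the compounds shown here, three have been measured in a toxicity assay on MT4 cells (Homo sapiens) for cytotoxicity, read by MTT assay, with a stated time of 5 days; a lower number here means that less compound is tolerated, a higher number that more compound is tolerated. Compound 1 `Cc1cnc(Nc2ccc(C#N)cc2)nc1Nc1c(F)cc(-c2ccoc2)cc1F` gives 4200 nM. Compound 2 `Cc1cc(-c2cccs2)cc(C)c1Nc1ccnc(Nc2ccc(C#N)cc2)n1` gives 10000 nM. Compound 3 `Cc1cc(-c2ccc3cc[nH]c3c2)cc(C)c1Nc1ccnc(Nc2ccc(C#N)cc2)n1` gives 5800 nM. Compound 2 has the highest of the three numbers: compound 3 is its nearest neighbour, and the difference to compound 1 is beyond the scatter. Among the compounds with values here, the one step measured between two compounds differing in a single place is a 1.7-fold lower number from compound 2 to compound 3 (0.24 log units; within the scatter), so that exchange left the result essentially unchanged.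

Compound 4 `COc1ncc(-c2cc(C)c(Nc3ccnc(Nc4ccc(C#N)cc4)n3)c(C)c2)cn1` is not yet measured. It differs from compound 2 in one place: 2-methoxypyrimidin-5-yl in place of thiophen-2-yl on an aromatic carbon. Within the data shown here, the only measured step that bears on this change is the one from compound 2 to compound 3, where another ring replaced the same thiophen-2-yl group at the same place and stayed within the scatter. On that basis no step beyond the scatter is expected in this assay, giving an expected 1.3-fold lower number from compound 2 to compound 4 (0.10 log units; within the scatter). Compound 4 is therefore estimated at 8000 nM, with a range from 3500 nM to 20000 nM.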

Compound 4, half-maximal cytotoxic concentration: 4800 nM
Compound 4: the middle estimate sits 1.7-fold (0.22 log units) above what was measured; low and high end bracket the measured number.
By their numbers in this assay, from the lowest: compounds 1, 4, 3 and 2 (each within the scatter of the next, the first and the last beyond it).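

In this assay, this position para to a large group now shows a step that goes beyond the scatter, though only modestly: placing 2-methoxypyrimidin-5-yl where thiophen-2-yl stood gives a 2.1-fold lower number from compound 2 to compound 4 (0.32 log units; beyond the scatter), whereas the earlier exchange for 1H-indol-6-yl stayed within the scatter. Exchanging 1H-indol-6-yl for 2-methoxypyrimidin-5-yl gives a 1.2-fold lower number from compound 3 to compound 4 (0.08 log units; within the scatter), which is also within the scatter, so these two rings cannot be told apart in this assay. No available measurement explains the step from thiophen-2-yl to 2-methoxypyrimidin-5-yl.

The compounds shown leave open whether the methoxy group or the ring itself matters here, a question that a pyrimidin-5-yl group without the methoxy would address. They also leave open how a non-ring group at this position, such as an amine or a carboxylic acid, would compare.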